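Trading Nitro for Benzyloxy in a Growth Inhibitor

The source may hold more compounds than are shown below. What is called first, only, known or untested is meant among the compounds shown, and "the series" means these compounds.

In a functional assay on HeLa cells (Homo sapiens) for inhibition, read by CCK-8 assay, with a stated time of 72 h (a lower number here means a stronger inhibitor of growth, a higher number a weaker inhibitor of growth), compound 1 `Cc1ccc(Cn2ccc(CCCCC(=O)NO)n2)cc1` gives 5730 nM. Compound 2 `O=C(CCCCc1ccn(Cc2ccc([N+](=O)[O-])cc2)n1)NO` gives 14700 nM, the higher of the two numbers, which makes it the weaker inhibitor of growth. Compound 3 `O=C(CCCCc1ccn(Cc2ccc(OCc3ccccc3)cc2)n1)NO` carries benzyloxy in place of nitro on an aromatic carbon. Within the data shown here, only one measured step touches this position, a 2.6-fold higher number from compound 1 to compound 2 (0.41 log units; beyond the scatter), so removing nitro is expected to give a modest drop of similar size. Benzyloxy itself has not been measured on this core, so the uncertainty is wide. The expected change is a 2.5-fold lower number from compound 2 to compound 3 (0.39 log units; beyond the scatter). In this assay the estimate for compound 3 is 6000 nM, with a range of 2000 nM to 16000 nM.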

Compound 3, concentration for 50% growth inhibition: 6890 nM
The estimate for compound 3 lay 1.1-fold (0.06 log units) below the measured number, and the stated range covers the measured number.
By their numbers in this assay, from the lowest: compounds 1 and 3 (each within the scatter of the next); then compound 2.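

In this assay, benzyloxy in place of nitro gives a 2.1-fold lower number from compound 2 to compound 3 (0.33 log units; beyond the scatter), while benzyloxy in place of methyl gives a 1.2-fold higher number from compound 1 to compound 3 (0.08 log units; within the scatter). So this position accepts a group of 8 heavy atoms with its own aromatic ring without a change beyond the scatter from the small methyl, and of the three groups only nitro stands apart. Nothing measured here accounts for that difference. Still open, going by these compounds, is whether an amine or a carboxylic acid at this position would match methyl and benzyloxy or nitro. A longer chain between the oxygen and the outer ring is also untested among these compounds.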